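A few compounds are considered here, and "the series" means these few. Any claim that something is new, unique, unknown or untested is made for them only; others in the source may bear on it.

The series rests on one shared core, carried in compound 1 `COc1ccc(-n2cc(CN3C(=O)C[C@@H]4CC[C@@]3(C)C4(C)C)nn2)cc1` and compound 2 `CC1(C)[C@H]2CC[C@]1(C)N(Cc1cn(-c3ccccc3Cl)nn1)C(=O)C2`. In a functional assay on PANC-1 cells (Homo sapiens) for inhibition, read by MTT assay, with a stated time of 24 h (on this read-out lower numbers stand for stronger inhibition and higher numbers for weaker inhibition), compound 1 gives 330 nM, and compound 2 gives 270 nM. Among the compounds with values here, compound 2 thus stands at one of only two numbers so far, and the step of a 1.2-fold lower number from compound 1 to compound 2 (0.09 log units; within the scatter) shows that the two cannot be told apart; that step put 2-chlorophenyl in place of 4-methoxyphenyl on an aromatic nitrogen.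

Compound 3 `COc1cccc(-n2cc(CN3C(=O)C[C@@H]4CC[C@@]3(C)C4(C)C)nn2)c1` has not yet been measured. It differs from compound 2 in one place: 3-methoxyphenyl in place of 2-chlorophenyl on an aromatic nitrogen. Within the data shown here, the only measured step that bears on this change is the exchange of 4-methoxyphenyl for 2-chlorophenyl on the same aromatic nitrogen, which gave a 1.2-fold lower number from compound 1 to compound 2 (0.09 log units; within the scatter) and left the number inside the scatter. Among the measured compounds shown here, with 3-methoxyphenyl rather than the 4-methoxyphenyl of compound 1, the data offer no step that points in either direction. Compound 3 is therefore expected to show a step of a 1.1-fold higher number from compound 2 to compound 3 (0.05 log units; within the scatter) in this assay, nothing beyond the scatter. The estimate for compound 3 is 300 nM, within a range of 150 nM to 650 nM.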

Compound 3, half-maximal inhibitory concentration: 860 nM
Beside the measured number, compound 3's estimate is 2.9-fold (0.46 log units) below it; measured number outside the range, above it.
By their numbers in this assay, from the lowest: compounds 2 and 1 (each within the scatter of the next); then compound 3.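

In this assay, the group on this aromatic nitrogen proves able to move the number beyond the scatter, which the earlier pair did not show: the step of a 3.2-fold higher number from compound 2 to compound 3 (0.50 log units; beyond the scatter) and the step of a 2.6-fold higher number from compound 1 to compound 3 (0.42 log units; beyond the scatter) both run upward, each of modest size. The second of these steps matters most, since 3-methoxyphenyl and 4-methoxyphenyl carry the same atoms and differ only in the numbered place of the methoxy group, so here that place alone separates the two numbers, whereas the very different 2-chlorophenyl and 4-methoxyphenyl remain within the scatter of each other. Nothing measured here accounts for this difference.

Going by these compounds, whether 3-chlorophenyl would also stand above 2-chlorophenyl, which would help to separate the numbered place from the kind of group, remains open. Also open, on these data alone, is what 2-methoxyphenyl, an unsubstituted phenyl, or a phenyl bearing an amine or a carboxylic acid would give on this nitrogen of the shared core.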